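Trading a methyl for a phenyl on the ring nitrogen

This account rests on a few compounds, and the source may have more. Where it says the series, first, only, none or still open, it means among the compounds named here.

The measured compounds, each with its inhibition value in an assay on isolated protein for inhibition of Fatty-acid amide hydrolase 1 (Homo sapiens), read by fluorescence, with a stated time of 30 min; a lower number here means a stronger inhibitor, a higher number a weaker inhibitor:
compound 1, `CCOC(=O)c1cc(-c2cccc(OC(=O)NC3CCCCC3)c2)n(CC)n1`, gives 101 nM;
compound 2, `CCOC(=O)c1cc(-c2ccc(OC(=O)NC3CCCCC3)cc2)n(-c2ccccc2)n1`, gives 268 nM;
compound 3, `Cn1nc(C(N)=O)cc1-c1ccc(OC(=O)NC2CCCCC2)cc1`, gives 209 nM.

Compound 3 has the second highest of these three numbers. Its value and that of compound 2 sit within the usual scatter of each other, so no order between them can be claimed. Compound 1 shows a lower number than compound 3, and that gap is beyond the scatter, so compound 1 is the stronger inhibitor of the two.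

The next compound, compound 4, `NC(=O)c1cc(-c2ccc(OC(=O)NC3CCCCC3)cc2)n(-c2ccccc2)n1`, keeps the carboxamide and the carbamate of compound 3 and differs in one place: phenyl in place of methyl on an aromatic nitrogen. For the measured compounds named here, no measured pair isolates this very change. Compound 2, which already carries a phenyl on the same nitrogen, lies close to compound 3 in this assay, which hints that the step from compound 3 to compound 4 need not move the number beyond the scatter.

For compound 4 the expectation in this assay is 250 nM, within a range of 80 nM to 800 nM, an estimated step of a 1.2-fold higher number from compound 3 to compound 4 (0.08 log units; within the scatter).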

Compound 4, half-maximal inhibitory concentration: 71 nM
Compound 4: the middle estimate sits 3.5-fold (0.55 log units) above what was measured; the whole stated range lies above it.
By their numbers in this assay, from the lowest: compounds 4 and 1 (each within the scatter of the next); then compounds 3 and 2 (each within the scatter of the next).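

On the aromatic nitrogen, phenyl in place of methyl is far from neutral when the carbamoyl group is on the ring: in this assay this change gives a 2.9-fold lower number from compound 3 to compound 4 (0.47 log units; beyond the scatter), so the six-carbon aromatic ring is tolerated here and goes with stronger inhibition. With the phenyl held fixed, amino in place of ethoxy on the carbonyl carbon gives a 3.8-fold lower number from compound 2 to compound 4 (0.58 log units; beyond the scatter), which shows that the closeness of compound 2 and compound 3 concealed two separate effects, since those two compounds differ in two places. Nothing measured here explains either step.

From the compounds shown here alone, whether a benzyl or a cyclohexyl on the same nitrogen would match the phenyl remains open. So does the outcome of replacing the carboxamide with a carboxylic acid while keeping the phenyl.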